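Urea in Place of Carbamate on a Shared Core

The source may hold more compounds than are shown below. What is called first, only, known or untested is meant among the compounds shown, and "the series" means these compounds.

The measured compounds, with their results in a functional assay on COLO 205 cells (Homo sapiens) for antiproliferative activity, read by MTT assay; a lower number here means a stronger inhibitor, a higher number a weaker inhibitor:
compound 1, `CCOC(=O)N1CCCc2cc(S(=O)(=O)N3CC(c4ccccc4)NC3=O)ccc21`, gives 2780 nM
compound 2, `CCCOC(=O)N1CCCc2cc(S(=O)(=O)N3CC(c4ccccc4)NC3=O)ccc21`, gives 1420 nM
compound 3, `O=C(c1ccccc1)N1CCCc2cc(S(=O)(=O)N3CC(c4ccccc4)NC3=O)ccc21`, gives 19300 nM

Among these three, compound 2 has the lowest number in this assay, but its nearest neighbour is compound 1, and the step of a 2.0-fold lower number from compound 1 to compound 2 (0.29 log units; within the scatter) stays within the scatter, so the two cannot be ranked. Compound 3 stands apart: the step of a 14-fold higher number from compound 2 to compound 3 (1.13 log units; beyond the scatter) is large, and the step of a 6.9-fold higher number from compound 1 to compound 3 (0.84 log units; beyond the scatter) points the same way.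

Compound 4, `O=C(NC1CCCCC1)N1CCCc2cc(S(=O)(=O)N3CC(c4ccccc4)NC3=O)ccc21`, is not yet measured. It differs from compound 2 in one place: cyclohexylamino in place of propoxy on a carbonyl carbon

Within the data shown here, the steps that bear on this change both concern the group on the same carbonyl carbon. Lengthening the alkoxy chain, a 2.0-fold lower number from compound 1 to compound 2 (0.29 log units; within the scatter), altered nothing beyond the scatter, whereas replacing the alkoxy group by phenyl, a 14-fold higher number from compound 2 to compound 3 (1.13 log units; beyond the scatter), weakened the compound strongly. Cyclohexylamino shares the ring with phenyl but not its aromatic character, and it brings a hydrogen-bond donor that no measured compound carries. On this basis a modest weakening from compound 2 is expected, smaller than the step to compound 3, with wide uncertainty; the expected step is a 2.5-fold higher number from compound 2 to compound 4 (0.39 log units; beyond the scatter). Compound 4 is therefore estimated at 3500 nM, within a range from 1000 nM to 12000 nM.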

Compound 4, half-maximal inhibitory concentration: 3890 nM
For compound 4 the middle estimate is 1.1-fold (0.05 log units) below the measured one; the range from low to high includes it.
By their numbers in this assay, from the lowest: compounds 2, 1 and 4 (each within the scatter of the next, the first and the last beyond it); then compound 3.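

In this assay, the step of a 5.0-fold lower number from compound 3 to compound 4 (0.70 log units; beyond the scatter) shows that the weakening seen with phenyl on this carbonyl carbon does not extend to every ring-bearing group, since cyclohexylamino, with its non-aromatic ring and its hydrogen-bond donor, recovers much of the lost ground. The propoxy group still has a modest edge, with the step of a 2.7-fold higher number from compound 2 to compound 4 (0.44 log units; beyond the scatter), whereas the step of a 1.4-fold higher number from compound 1 to compound 4 (0.15 log units; within the scatter) stays within the scatter, so cyclohexylamino cannot be separated from ethoxy, and a group joined through nitrogen can sit in the same range as a short alkoxy group. Nothing among the data shown explains these differences.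

The compounds shown leave open whether the ring or the amide hydrogen of cyclohexylamino accounts for its distance from phenyl, a question that cyclohexyloxy, phenylamino or a straight-chain propylamino on the same carbonyl carbon would help to separate. They also leave open whether a longer alkoxy chain such as butoxy or pentyloxy would give a number clearly below those of the ethoxy and propoxy compounds.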